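Swapping Furan for Pyridine on a Shared Core

The source may hold more compounds than are shown below. What is called first, only, known or untested is meant among the compounds shown, and "the series" means these compounds.

Compound 1, `CN(C)c1ccc(Nc2nccc(-c3ccccn3)n2)cc1`, gives 3300 nM in a functional assay for inhibition, with Homo sapiens as the target; a lower number here means a stronger inhibitor, a higher number a weaker inhibitor.
Compound 2, `CN(C)c1ccc(Nc2nccc(-c3ccco3)n2)cc1`, gives 1900 nM in this assay.
Compound 3, `COc1cccc(Nc2nccc(-c3ccco3)n2)c1`, gives 400 nM in this assay.

Compound 2 and compound 1 differ only by pyridin-2-yl in place of furan-2-yl on an aromatic carbon, and that change made a 1.7-fold higher number from compound 2 to compound 1 (0.24 log units; within the scatter). Compound 3 differs from compound 2 in more than one place; the difference between the two cores is not broken down here. Compound 3 stands lowest of the three, beyond the scatter from both others.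

Compound 4, `COc1cccc(Nc2nccc(-c3ccccn3)n2)c1`, differs from compound 3 by pyridin-2-yl in place of furan-2-yl on an aromatic carbon. This is the same kind of change as before, though around the place one description says meta to a group of 9 heavy atoms and the other meta to a large group. Resting on a 1.7-fold higher number from compound 2 to compound 1 (0.24 log units; within the scatter), the expected step is a 1.7-fold higher number from compound 3 to compound 4 (0.23 log units; within the scatter). Compound 4 is therefore estimated at 680 nM, between 300 nM and 1600 nM.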

Compound 4, half-maximal inhibitory concentration: 200 nM
For compound 4 the middle estimate is 3.4-fold (0.53 log units) above the measured one, outside the stated range (below it).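

On the other core, pyridin-2-yl in place of furan-2-yl gives a 2.0-fold lower number from compound 3 to compound 4 (0.30 log units; within the scatter). Within the data shown here, each step taken alone lies within the scatter, yet the two steps are further apart than the scatter allows, so in this assay this change does not carry over from one core to the other as a single fixed step: the same change on two cores in this assay, a 1.7-fold higher number (0.24 log units; within the scatter) from compound 2 to compound 1 and a 2.0-fold lower number (0.30 log units; within the scatter) from compound 3 to compound 4, 3.5-fold (0.54 log units) apart, beyond the scatter of two such steps With only two pairs, this does not show which difference between the cores lies behind the gap, nor that the change by itself moves the number on either core.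

Going by these compounds, whether the same gap appears on further cores stays open. On these data alone, how an amine or a carboxylic acid in place of the furan-2-yl would compare also stays open.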